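The compounds below may be only part of what the source reports. "The series", "measured", "known", "first", "only" and "open" are said of these compounds alone.

Three compounds have so far been followed in an ADME assay for pharmacokinetics, read by LC-MS, in phosphate buffer, with a stated time of 72 h, at pH 7.4, tested at 250 uM; a higher number here means that the compound lasts longer, a lower number that the compound disappears faster. Compound 1 `C=CC(=O)Oc1cc(C(F)(F)F)cc(C(F)(F)F)c1` carries a (vinylcarbonyl)oxy group on its aromatic ring, and in this assay compound 1 gives < 0.017 h, which is a limit of the assay and not a number. Compound 2 `C=Cc1cc(C(F)(F)F)cc(C(F)(F)F)c1` has a vinyl group in that place, and compound 2 gives > 50 h, again a limit. Compound 3 `FC(F)(F)c1cc(C2CO2)cc(C(F)(F)F)c1` has an oxiran-2-yl group there, and compound 3 gives > 50 h, also a limit. Both measured steps away from the ester are large: an at least 2900-fold higher number from compound 1 to compound 2 (3.46 log units; beyond the scatter) and an at least 2900-fold higher number from compound 1 to compound 3 (3.46 log units; beyond the scatter). Between the other two the picture is a step that the two limits leave unreadable from compound 2 to compound 3. Compound 3 therefore stands at the upper edge of what the assay reports, sharing that place with compound 2 (the limit of > 50 h in this assay, at which 2 of the 3 values shown sit), while compound 1 sits at the lower edge (the limit of < 0.017 h in this assay, at which 1 of the 3 values shown sits).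

The next compound, compound 4 `Fc1cc(C(F)(F)F)cc(C(F)(F)F)c1`, differs from compound 3 by fluoro in place of oxiran-2-yl on an aromatic carbon. Among the compounds with values here, none of the measured steps involves a fluoro group, and the only steps that are readable concern the loss of the ester. Compound 4 is expected to remain at the upper edge, and the expected step is a step that the limit leaves unreadable from compound 3 to compound 4, not readable beyond the limit. The estimate for compound 4 is 60 h, between 20 h and 200 h.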

Compound 4, half-life: > 50 h
Compound 4 was reported as a limit (the forecaster's own chance of this, stated with the estimate: 85%); the middle value does not contradict the limit.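

Fluoro, a single atom with no ring and no hydrogen-bond acceptor, now joins vinyl and oxiran-2-yl at the upper edge of this assay, so a third, much smaller replacement for the ester on this aromatic carbon also reaches that edge: the limit of > 50 h in this assay, at which 3 of the 4 values shown sit. The change away from the ester again gives an at least 2900-fold higher number from compound 1 to compound 4 (3.46 log units; beyond the scatter). The steps among compound 2, compound 3 and compound 4 cannot be read, so these three compounds cannot be ranked against one another.

Going by these compounds, how long any of these three compounds lasts past the limit remains open. Also open, on these data alone, is whether fast disappearance needs the whole (vinylcarbonyl)oxy group, or whether a saturated ester such as propanoyloxy, or an amine on the same carbon, would also leave the shared core short-lived.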